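A few compounds are considered here, and "the series" means these few. Any claim that something is new, unique, unknown or untested is made for them only; others in the source may bear on it.

Measured compounds:
compound 1 `COCCNc1nccc2c(-c3ccnc(NC4CCCC4)n3)c(-c3cccc(Cl)c3)nn12`, in an ADME assay on Vero cells (Chlorocebus sabaeus) for cytotoxicity; a lower number here means that less compound is tolerated, a higher number that more compound is tolerated: > 40000 nM
compound 2 `COc1ccc(-c2nn3c(NC4CCCC4)nccc3c2-c2ccnc(NC3CCCC3)n2)cc1`, in this assay: > 40000 nM

The value of compound 1 is a limit of the assay and not a number. The value of compound 2 is likewise a limit of the assay and not a number, so no figure places compound 2 within the range shown; it sits at the limit of > 40000 nM in this assay, at which 2 of the 2 values shown sit, and nothing more can be said of where it stands.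

Compound 3 `c1cc(-c2c(-c3ccc(OCC4CC4)cc3)nn3c(NC4CCCC4)nccc23)nc(NC2CCCC2)n1` differs from compound 2 in that (cyclopropyl in place of hydrogen on a saturated chain carbon bound to an oxygen on an aromatic ring). Going by the values given here, no pair of measured compounds shows this change, so there is no measured step to lean on. The step of a number no higher from compound 2 to compound 3 (the limit leaves the size open) is expected to stay within the usual scatter, with no direction favoured. Compound 3 is therefore estimated at 40000 nM, in a range from 20000 nM to 80000 nM, and a limit rather than a number is the more likely report.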

Compound 3, half-maximal cytotoxic concentration: > 40000 nM
Compound 3 was reported as a limit; the forecaster's own chance of this, stated with the estimate: 70%; the middle value sits exactly at the limit.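

Compound 2 and compound 3 are both reported only as limits of the assay, so no step can be read between them: the limit of > 40000 nM in this assay, at which 3 of the 3 values shown sit. The compounds shown leave open the actual half-maximal cytotoxic concentration of each compound, and whether cyclopropyl in place of hydrogen alters it at all.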